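The source may report more compounds than this note shows. Statements on the series, on what has been measured and on what is new or still open speak of the compounds shown alone.

Measured so far:
compound 1, `Cc1ccc(Nc2nc(Cl)nc3c2ncn3Cc2ccc(C(=O)Nc3ccccc3N)cc2)cc1`, gives 76.2% in a functional assay on HepG2 cells (Homo sapiens) for antiproliferative activity, read by CCK-8 assay, with a stated time of 72 h, tested at 2 uM; on this read-out lower numbers stand for a weaker effect and higher numbers for a stronger effect at the one concentration tested.
compound 2, `CC1CCN(c2nc(Cl)nc3c2ncn3Cc2ccc(/C=C/C(=O)Nc3ccccc3N)cc2)CC1`, gives 8.73% in this assay.

Compound 2 stands lowest of the two numbers; its nearest neighbour is compound 1, whose number is higher by a margin well beyond the usual scatter. Compound 3, `Cc1ccc(Nc2nc(Cl)nc3c2ncn3Cc2ccc(/C=C/C(=O)Nc3ccccc3N)cc2)cc1`, has not yet been measured. It differs from compound 2 in one place: (4-methylphenyl)amino in place of 4-methylpiperidin-1-yl on an aromatic carbon. The group that enters is the same (4-methylphenyl)amino group that compound 1 carries, so compound 3 sits between the two measured compounds in structure, holding the aromatic amine of compound 1 and the rest of compound 2. Since compound 1 gives 76.2% and compound 2 gives 8.73%, the change is expected to move the number upward by a large step, beyond the scatter. Because compound 2 gives 8.73% while compound 1 reaches 76.2%, the expected step of a number 46.3 percentage points higher from compound 2 to compound 3 (beyond the scatter) is taken to be strongly positive. For compound 3 the expected value is 55%, with a range from 20% to 85%.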

Compound 3, a percentage reported as inhibition, at one concentration (the size of the read-out at that concentration, not a potency): 33.6%
Compound 3: the middle estimate sits 21.4 percentage points above what was measured; the measured number falls inside the stated range.
By their numbers in this assay, from the lowest: compound 2; then compound 3; then compound 1.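

In this assay, with the 2-((2-aminophenyl)carbamoyl)ethenyl group held constant, (4-methylphenyl)amino in place of 4-methylpiperidin-1-yl on the aromatic carbon gives a number 24.9 percentage points higher from compound 2 to compound 3 (beyond the scatter), so the change at this position alone moves the read-out beyond the scatter. With (4-methylphenyl)amino held constant, 2-((2-aminophenyl)carbamoyl)ethenyl in place of (2-aminophenyl)carbamoyl gives a number 42.6 percentage points lower from compound 1 to compound 3 (beyond the scatter), which shows that the (4-methylphenyl)amino group by itself does not carry a compound to the level of compound 1, at 76.2%. No measurement at hand accounts for either step.

The compounds shown leave open how 4-methylpiperidin-1-yl behaves alongside the (2-aminophenyl)carbamoyl group, so it cannot be said whether the two changes simply add or depend on each other. They also leave open how other groups on the same aromatic carbon would read, such as a morpholine, an open-chain amine or a phenylamino group carrying a methoxy group, and whether the trend seen with these two groups would extend to them.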